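Swapping the ether-acid chain of compound 1 for a shorter acid

This account rests on a few compounds, and the source may have more. Where it says the series, first, only, none or still open, it means among the compounds named here.

Measured so far, in a functional assay on FaDu cells (Homo sapiens) for cytotoxicity, read by MTT assay, with a stated time of 72 h; a lower number here means that less compound is tolerated, a higher number that more compound is tolerated:
- compound 1 `COc1ccc(NC(=O)C(=O)c2cn(C(C)(C)COCC(=O)O)c3ccccc23)cn1` gives > 10000 nM, a limit of the assay rather than a number.
- compound 2 `COCCn1cc(C(=O)C(=O)Nc2ccc(OC)nc2)c2cc(Cl)ccc21` gives > 10000 nM, again a limit.
- compound 3 `COc1ccc(NC(=O)C(=O)c2cn(C(C)C)c3cnccc23)cn1` gives > 10000 nM, again a limit.

The three measured compounds share a core and differ in the group on the aromatic nitrogen and in the ring that carries it. None of them gave a number in this assay. Compound 1 stands exactly where the other two stand: at the limit, (the limit of > 10000 nM in this assay, at which 3 of the 3 values shown sit). So there is no difference between any pair of the three, only the same limit in each case.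

Compound 4 `COc1ccc(NC(=O)C(=O)c2cn(CCC(=O)O)c3ccccc23)cn1` is not yet measured. It differs from compound 1 in one place: a group of 5 heavy atoms (3 carbon, 2 oxygen; no ring) in place of a group of 9 heavy atoms (6 carbon, 3 oxygen; no ring), on an aromatic nitrogen. The 2-carboxyethyl group keeps a hydrogen-bond donor and an acid-type double bond but is shorter than the group it replaces.

Among the measured compounds shown here, no step between measured compounds is known, so there is nothing to set a scale for this change. Since compound 1 sits at the limit, (the limit of > 10000 nM in this assay, at which 3 of the 3 values shown sit), and every measured neighbour does too, no change beyond the scatter is expected in this assay.

Compound 4 is expected to give 20000 nM, in the range 10000 nM to 100000 nM, most likely reported only as a limit again. For the measured compounds named here, the step this estimate implies is a step that the limit leaves unreadable from compound 1 to compound 4, expected to be no real step at all.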

Compound 4, concentration lethal to 50% of the cells in the FaDu assay: > 10000 nM
Compound 4: a limit, no number; the forecaster's own chance of this, stated with the estimate: 85%; the middle value does not contradict the limit.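

In the FaDu assay and in a physicochemical assay for solubility, in phosphate buffer, at pH 7.4 (a lower number here means a less soluble compound, a higher number a more soluble compound), no step can be read between compound 1 and compound 4: both compounds give only limits of the assay, not numbers. In the physicochemical assay compound 1 gives <= 200000 nM, a limit of the assay. In the physicochemical assay compound 4 gives <= 200000 nM, again a limit. The compounds shown leave open whether the change of group on the aromatic nitrogen moves either read-out at all, and how far each compound's true value lies from its limit.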